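The source may report more compounds than this note shows. Statements on the series, on what has been measured and on what is new or still open speak of the compounds shown alone.

In a functional assay on the whole organism with Rattus norvegicus as the target, at a dose of 20 mg/kg by the oral route (a lower number here means less inhibition, a higher number more inhibition at the dose given (going by the name of the read-out)), compound 1, `O=C(/C=C1\CCc2ccc(F)cc21)NCCO`, gives 78%, the highest of the three numbers measured. Compound 2, `NC(=O)/C=C1\CCc2cc(F)cc(F)c21`, gives 55% in this assay, a number that lies beyond the scatter below compound 1. Compound 3, `COc1ccc2c(c1)/C(=C/C(N)=O)CC2`, gives 3%, far below the other two. Compound 1 therefore stands alone at the top of this small set, with both other compounds beyond the scatter beneath it.

Compound 4, `O=C(/C=C1\CCc2ccc(F)cc21)NC1CC1`, has not yet been measured in this assay. It differs from compound 1 in one place: cyclopropyl in place of 2-hydroxyethyl on an amide-type nitrogen. Going by the values given here, no measured pair of compounds shows what this particular change does, so any expectation rests on the change alone and carries wide uncertainty. For compound 4 the expected step is a number 16 percentage points lower from compound 1 to compound 4 (beyond the scatter), a modest move downward whose size may or may not reach beyond the scatter. Compound 4 is thus expected to give 62% in this assay, within a range from 30% to 85%.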

Compound 4, a percentage reported as inhibition, in the whole organism at one dose (the size of the read-out at that dose, not a potency): 7%
Compound 4: middle estimate off by 55 percentage points, on the high side; measured number below the stated range.
By their numbers in this assay, from the lowest: compounds 3 and 4 (each within the scatter of the next); then compound 2; then compound 1.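

In this assay the swap of 2-hydroxyethyl for cyclopropyl on the amide-type nitrogen gives a number 71 percentage points lower from compound 1 to compound 4 (beyond the scatter) so this position is highly sensitive to the group it carries, even though both groups have 3 heavy atoms and the rest of the molecule stays the same. The core of compound 1 is therefore not enough on its own to keep the high number at this dose. This single pair cannot separate the loss of the hydroxyl-bearing chain from the arrival of the three-membered ring, and nothing shown explains the step.

A plain propyl chain on this nitrogen would help to separate those two parts of the change, as would a 2-methoxyethyl or 3-hydroxypropyl group. Going by these compounds, whether the same swap has a similar effect with other groups on the core also remains open.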